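The compounds below may be only part of what the source reports. "The series", "measured", "known", "first", "only" and "open" are said of these compounds alone.

Measured in a functional assay with Homo sapiens as the target; a lower number here means a stronger inhibitor, a higher number a weaker inhibitor:
- Compound 1 `CC(C)[C@H](NC(=O)COc1cccc2ccccc12)C(=O)N[C@@H](CC(=O)O)C(=O)COc1c(F)cccc1F`: > 100000 nM, a limit of the assay
- Compound 2 `CC(C)[C@H](NC(=O)COc1cccc2ccccc12)C(=O)N[C@@H](CC(=O)O)C(=O)COc1ccc(F)c(F)c1`: 16200 nM
- Compound 3 `CC(C)[C@H](NC(=O)COc1cccc2ccccc12)C(=O)N[C@@H](CC(=O)O)C(=O)COc1c(F)cc(F)cc1F`: 14900 nM

On the numbers shown, compound 3 sits level with its only numerical neighbour: a 1.1-fold lower number from compound 2 to compound 3 (0.04 log units; within the scatter). Compound 4 `CC(C)[C@H](NC(=O)COc1cccc2ccccc12)C(=O)N[C@@H](CC(=O)O)C(=O)COc1cccc(C(F)(F)F)c1F` differs from compound 3 in one place, with 2-fluoro-3-(trifluoromethyl)phenyl in place of 2,4,6-trifluorophenyl on an oxygen on a saturated carbon.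

For the measured compounds named here, no measured compound carries a trifluoromethyl group, so the closest guidance comes from exchanges among the fluorinated phenyl groups. One such exchange, 2,4,6-trifluorophenyl in place of 3,4-difluorophenyl, stayed within the scatter: a 1.1-fold lower number from compound 2 to compound 3 (0.04 log units; within the scatter). The two steps away from 2,6-difluorophenyl went beyond it: an at least 6.1-fold lower number from compound 1 to compound 2 (0.79 log units; beyond the scatter) and an at least 6.7-fold lower number from compound 1 to compound 3 (0.82 log units; beyond the scatter). This group can therefore be silent, but not always.

With only these three compounds, the expectation in this assay is for little or no change beyond the scatter, with more room towards a higher number than a lower one. The expected change is a 1.3-fold higher number from compound 3 to compound 4 (0.13 log units; within the scatter). For compound 4 the estimated value is 20000 nM, with an expected range of 7000 nM to 70000 nM.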

Compound 4, half-maximal inhibitory concentration: 18200 nM
Compound 4: the middle estimate sits 1.1-fold (0.04 log units) above what was measured, and the stated range covers the measured number.
By their numbers in this assay, from the lowest: compounds 3, 2 and 4 (each within the scatter of the next). At a limit, above all of these: compound 1.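

In this assay, the 11 heavy atoms of 2-fluoro-3-(trifluoromethyl)phenyl on this oxygen read the same as the 9 of 2,4,6-trifluorophenyl, with a 1.2-fold higher number from compound 3 to compound 4 (0.09 log units; within the scatter), and the exchange for 3,4-difluorophenyl reads the same way, with a 1.1-fold higher number from compound 2 to compound 4 (0.05 log units; within the scatter). The level reading seen earlier for two fluorophenyl groups therefore extends to a group carrying trifluoromethyl, and among the four compounds only compound 1, with its 2,6-difluorophenyl, goes against it, with an at least 5.4-fold lower number from compound 1 to compound 4 (0.73 log units; beyond the scatter). The size of that last step is only a bound, since compound 1 stands at a limit of the assay: the limit of > 100000 nM in this assay, at which 1 of the 4 values shown sits.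

As far as these compounds go, whether the same level reading would hold for a phenyl group without fluorine, or for one carrying a methoxy group, a nitrile or an amine, remains open. Also open is how the shared core would respond if a saturated chain replaced the phenyl group on this oxygen, and why 2,6-difluorophenyl alone among these groups sits apart.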